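Replacing dipropylamino with pyrrolidin-1-yl on a methylated core

This account rests on a few compounds, and the source may have more. Where it says the series, first, only, none or still open, it means among the compounds named here.

The study covers four compounds on a shared core. Compound 1 `CCCN(CCC)c1nc(Cc2c(F)cccc2F)cc(=O)[nH]1` carries a dipropylamino group; compound 2 `O=c1cc(Cc2c(F)cccc2F)nc(N2CCCC2)[nH]1` carries pyrrolidin-1-yl in its place, the change being (pyrrolidin-1-yl in place of dipropylamino on an aromatic carbon). Compound 3 `CCCN(CCC)c1nc(Cc2c(F)cccc2F)c(C)c(=O)[nH]1` differs from compound 1 by methyl in place of hydrogen on an aromatic carbon. Compound 4 `Cc1c(Cc2c(F)cccc2F)nc(N2CCCC2)[nH]c1=O` is not yet measured and differs from compound 3 by pyrrolidin-1-yl in place of dipropylamino on an aromatic carbon; the place differs from the earlier change in being para to a methyl group (1 heavy atom), so this is the same kind of change rather than the same change.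

In an ADME assay on MT4 cells (Homo sapiens) for cytotoxicity, read by MTT assay, with a stated time of 4 days (on this read-out higher numbers stand for lower toxicity in this test and lower numbers for higher toxicity in this test), compound 1 reaches only a limit of > 78000 nM. Compound 2 likewise reaches only a limit of > 86000 nM. Compound 3 also gives only a limit, > 74000 nM. Accordingly, a step that the two limits leave unreadable from compound 1 to compound 2 and a step that the two limits leave unreadable from compound 1 to compound 3 cannot be sized, as the three values sit at the limit of > 74000 nM in this assay, at which 1 of the 3 values shown sits, the limit of > 78000 nM in this assay, at which 1 of the 3 values shown sits, and (the limit of > 86000 nM in this assay, at which 1 of the 3 values shown sits).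

Since the earlier step was a step that the two limits leave unreadable from compound 1 to compound 2, the same kind of change is expected to give a step that the limit leaves unreadable from compound 3 to compound 4. Compound 4 is therefore estimated at 80000 nM, between 40000 nM and 160000 nM, most likely reported again as a limit in this assay.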

Compound 4, half-maximal cytotoxic concentration: > 82000 nM
Compound 4 ended at the assay's limit; the forecaster's own chance of this, stated with the estimate: 85%; at least 1.0-fold (0.01 log units) between middle value and limit.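

In this assay compound 4 gives only a limit, so no step can be read from compound 3 to compound 4 or from compound 2 to compound 4. The compounds shown leave open whether pyrrolidin-1-yl in place of dipropylamino, or methyl in place of hydrogen, changes the half-maximal cytotoxic concentration at all.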